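Replacing 2-nitrophenyl with 3-fluorophenyl on a carbonyl carbon

The source may hold more compounds than are shown below. What is called first, only, known or untested is meant among the compounds shown, and "the series" means these compounds.

Compound 1 `Nc1nc(Nc2ccc(S(N)(=O)=O)cc2)sc1C(=O)c1cccnc1`: 20000 nM
Compound 2 `Nc1nc(Nc2ccc(S(N)(=O)=O)cc2)sc1C(=O)c1ccccc1[N+](=O)[O-]`: 20000 nM

Among the measured compounds shown here, in a functional assay on GC-1 cells (Mus musculus) for cytotoxicity, read by MTT assay, with a stated time of 72 h (on this read-out lower numbers stand for stronger inhibition and higher numbers for weaker inhibition), compound 2 gives 20000 nM, which puts it level with compound 1, the only other compound measured so far. The next compound is compound 3 `Nc1nc(Nc2ccc(S(N)(=O)=O)cc2)sc1C(=O)c1cccc(F)c1`. The change is 3-fluorophenyl in place of 2-nitrophenyl on a carbonyl carbon, so 3-fluorophenyl takes the place of 2-nitrophenyl on a carbonyl carbon, while the rest of the molecule stays the same. For the measured compounds named here, one measured step bears on this swap: no change at the digits printed from compound 1 to compound 2 (within the scatter). It was also made on the carbonyl carbon, replacing pyridin-3-yl with 2-nitrophenyl. A single step is thin evidence, but it gives no reason to expect a shift in either direction beyond the scatter in this assay. The expected size of the change is a 1.1-fold lower number from compound 2 to compound 3 (0.05 log units; within the scatter). Compound 3 is estimated at 18000 nM, with an expected range of 8000 nM to 40000 nM.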

Compound 3, half-maximal inhibitory concentration: 6400 nM
Estimate against measurement, compound 3: 2.8-fold (0.45 log units) above; the measured number lies below the stated range.
By their numbers in this assay, from the lowest: compound 3; then compounds 1 and 2 (each within the scatter of the next).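

In this assay, among the compounds shown here, the group on the carbonyl carbon can move the number after all: 3-fluorophenyl is the first group here to do so, with a 3.1-fold lower number from compound 2 to compound 3 (0.49 log units; beyond the scatter) and a 3.1-fold lower number from compound 1 to compound 3 (0.49 log units; beyond the scatter). The step is modest, but it is the same from both starting points, so 2-nitrophenyl and pyridin-3-yl, which stood level, both give way to 3-fluorophenyl in the same measure. Nothing available here explains this gain.

For the compounds shown here, with only one fluorine-bearing group in the set, it remains open whether the gain comes from the fluorine itself or from the plain carbon ring that carries it. An unsubstituted phenyl would help to separate the two, and a chlorine in place of the fluorine or a methoxy group on the ring would show how far the gain extends.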